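Acyl branching at compound 3: propyl to isopropyl

The source may report more compounds than this note shows. Statements on the series, on what has been measured and on what is new or still open speak of the compounds shown alone.

Compound 1 `CCC(=O)NC[C@@H]1CC1c1cccc2oc(CCCCc3ccccc3)cc12` gives 2.1 nM in an assay on NIH3T3 cells for binding affinity to melatonin receptor type 1A (Homo sapiens); a higher number here means a weaker inhibitor, a lower number a stronger inhibitor. Compound 2 `CC(=O)NCCCc1cccc2oc(CCCCc3ccccc3)cc12` gives 19 nM, and compound 3 `CCCC(=O)NCCCc1cccc2oc(CCCCc3ccccc3)cc12` gives 16 nM. Compound 3 thus carries the second highest number of the three: compound 2 lies nearest, within the scatter, while compound 1 lies lower by a margin beyond it. The steps are a 9.0-fold higher number from compound 1 to compound 2 (0.96 log units; beyond the scatter), a 7.6-fold higher number from compound 1 to compound 3 (0.88 log units; beyond the scatter) and a 1.2-fold lower number from compound 2 to compound 3 (0.07 log units; within the scatter). Compound 4 `CC(C)C(=O)NCCCc1cccc2oc(CCCCc3ccccc3)cc12` differs from compound 3 by isopropyl in place of propyl on a carbonyl carbon. Going by the values given here, only the step from compound 2 to compound 3, which also alters the substituent on the carbonyl carbon and stays within the scatter, bears on this; no measured pair branches that substituent. The expected step is no change at the digits printed from compound 3 to compound 4 (within the scatter). For compound 4 the estimate is 16 nM, range 6 nM to 40 nM.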

Compound 4, inhibition constant: 3.7 nM
Beside the measured number, compound 4's estimate is 4.3-fold (0.64 log units) above it; measured number below the stated range.
By their numbers in this assay, from the lowest: compounds 1 and 4 (each within the scatter of the next); then compounds 3 and 2 (each within the scatter of the next).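

In this assay, the substituent on the carbonyl carbon proves sensitive to branching, although going from methyl to propyl had shown nothing: isopropyl in place of propyl gives a 4.3-fold lower number from compound 3 to compound 4 (0.64 log units; beyond the scatter), and isopropyl in place of methyl gives a 5.1-fold lower number from compound 2 to compound 4 (0.71 log units; beyond the scatter). With isopropyl, the open 3-((isopropylcarbonyl)amino)propyl chain also stands within the scatter of the cyclopropyl chain, with a 1.8-fold higher number from compound 1 to compound 4 (0.25 log units; within the scatter). Nothing measured here accounts for the effect of branching.

Going by these compounds, whether tert-butyl or cyclopropyl on the carbonyl carbon would give a similar step remains open. So does the effect of isopropyl on the carbonyl carbon within the cyclopropyl chain of compound 1.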